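Amino for Nitro on a Methylated Oxime Core

A few compounds are considered here, and "the series" means these few. Any claim that something is new, unique, unknown or untested is made for them only; others in the source may bear on it.

Compound 1 `COc1ccc(-c2c(-c3cc(OC)c(OC)c(OC)c3)ss/c2=N/O)cc1[N+](=O)[O-]` and compound 2 `COc1ccc(-c2c(-c3cc(OC)c(OC)c(OC)c3)ss/c2=N/O)cc1N` share an oxime core and differ only where (amino in place of nitro on an aromatic carbon). In a functional assay on HT-1080 cells (Homo sapiens) for antiproliferative activity, read by MTT assay, with a stated time of 72 h (a higher number here means a weaker inhibitor, a lower number a stronger inhibitor), compound 1 gives 3030 nM, and compound 2 gives 2910 nM, so that a 1.0-fold lower number from compound 1 to compound 2 (0.02 log units; within the scatter). Compound 3 `CO/N=c1/ssc(-c2cc(OC)c(OC)c(OC)c2)c1-c1ccc(OC)c([N+](=O)[O-])c1` carries the core of compound 1 altered at one point, (methyl in place of hydrogen on an oxygen), and here an at least 33-fold higher number from compound 1 to compound 3 (1.51 log units; beyond the scatter). For compound 3 this assay reports only a limit, > 100000 nM, and that limit is the limit of > 100000 nM in this assay, at which 1 of the 3 values shown sits. Compound 4 `CO/N=c1/ssc(-c2cc(OC)c(OC)c(OC)c2)c1-c1ccc(OC)c(N)c1` differs from compound 3 by the same change that turns compound 1 into compound 2: amino in place of nitro on an aromatic carbon, at a place described in the same words. Since that change left the number almost unchanged on the oxime core, the expectation is a step that the limit leaves unreadable from compound 3 to compound 4, and compound 4 is estimated at 120000 nM, most likely again reported as a limit.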

Compound 4, half-maximal inhibitory concentration: 915 nM
Compound 4: middle estimate off by 130-fold (2.12 log units), on the high side, outside the stated range (below it).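

In this assay, amino in place of nitro gives an at least 100-fold lower number from compound 3 to compound 4 (2.03 log units; beyond the scatter) on the core of compound 3, and this differs sharply from the same change on the oxime core: the same change on two cores in this assay, a 1.0-fold lower number (0.02 log units; within the scatter) from compound 1 to compound 2 and an at least 100-fold lower number (2.03 log units; beyond the scatter) from compound 3 to compound 4, at least 100-fold (2.02 log units) apart, beyond the scatter of two such steps With amino on the aromatic carbon, methyl in place of hydrogen on an oxygen gives a 3.2-fold lower number from compound 2 to compound 4 (0.50 log units; beyond the scatter), so this change also fails to carry over unchanged: the same change on two cores in this assay, an at least 33-fold higher number (1.51 log units; beyond the scatter) from compound 1 to compound 3 and a 3.2-fold lower number (0.50 log units; beyond the scatter) from compound 2 to compound 4, at least 100-fold (2.02 log units) apart, beyond the scatter of two such steps Compound 3 gives > 100000 nM, which is a limit and not a number; these two pairs give no reason for the gap and no rule for other cores.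

The compounds shown leave open how a hydroxyl or a methylamino group on that aromatic carbon would compare with nitro and amino. They also leave open how an ethyl group on the oxygen would compare with methyl.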